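The source may hold more compounds than are shown below. What is called first, only, known or untested is meant among the compounds shown, and "the series" means these compounds.

In a functional assay on PC-3 cells (Homo sapiens) for antiproliferative activity, read by sulforhodamine B assay, with a stated time of 48 h (on this read-out higher numbers stand for weaker inhibition and lower numbers for stronger inhibition), compound 1 `C[C@H]1N=C2C[C@H]3C[C@H](C3(C)C)[C@@]2(C)OC1=O` gives 42000 nM, and in this assay compound 2 `CC1(C)[C@@H]2CC3=N[C@@H](CCC(=O)O)C(=O)O[C@@]3(C)[C@H]1C2` gives 42000 nM. Compound 2 thus stands level with compound 1 at the digits shown, the two values lying within the scatter of each other, with no further compound to place it against. Compound 3 `C[C@@H]1N=C2C[C@@H]3C[C@@H](C3(C)C)[C@]2(C)OC1=O` differs from compound 2 in one place: hydrogen in place of carboxymethyl on a saturated chain carbon bound to a saturated ring carbon. Going by the values given here, no step between measured compounds is available to guide this change; what the two measured values show is that the 2-carboxyethyl chain of compound 2 and the methyl of compound 1 sit at the same level, and compound 3 carries the methyl. On that basis the change from compound 2 to compound 3 is expected to give no shift beyond the scatter, no change at the digits printed from compound 2 to compound 3 (within the scatter). Compound 3 is therefore estimated at 42000 nM, within a range from 15000 nM to 120000 nM.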

Compound 3, half-maximal inhibitory concentration: 149000 nM
Compound 3: the middle estimate sits 3.5-fold (0.55 log units) below what was measured, outside the stated range (above it).
By their numbers in this assay, from the lowest: compounds 1 and 2 (each within the scatter of the next); then compound 3.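

In this assay, going by these compounds alone, the mirror-image pair gives a 3.5-fold higher number from compound 1 to compound 3 (0.55 log units; beyond the scatter), so on this shared core the configuration as drawn moves the number, which the level values of the earlier compounds could not show. This gap can be put down to configuration alone because nothing else separates the two compounds: the fact that compounds 1 and 3 differ only in the configuration as drawn

The step of a 3.5-fold higher number from compound 2 to compound 3 (0.55 log units; beyond the scatter) has the same size, so with compound 2 level with compound 1, the change from 2-carboxyethyl to methyl cannot be read apart from configuration on this step.

The compounds shown leave open whether the 2-carboxyethyl chain would hold its level on the configuration of compound 3. They also leave open whether an amine or a longer carbon chain at this place would shift the number on either configuration.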